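Dropping a Chloro Group: Estimating Compound 4

The source may report more compounds than this note shows. Statements on the series, on what has been measured and on what is new or still open speak of the compounds shown alone.

Compound 1 `COc1cccc(-c2nn(-c3ccccc3)cc2C(Nc2nc3ccccc3s2)c2c(O)ccc3ccccc23)c1` gives 14900 nM in a functional assay on HeLa cells (Homo sapiens) for antiproliferative activity, read by MTT assay, with a stated time of 48 h; on this read-out higher numbers stand for weaker inhibition and lower numbers for stronger inhibition. Compound 2 `COc1cccc(-c2nn(-c3ccccc3)cc2C(Nc2nc3ccc(Cl)cc3s2)c2c(O)ccc3ccccc23)c1` gives 30000 nM in this assay. Compound 3 `Oc1ccc2ccccc2c1C(Nc1nc2ccc(Cl)cc2s1)c1cn(-c2ccccc2)nc1-c1cccc(Cl)c1` gives 18300 nM in this assay.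

Compound 4 `Oc1ccc2ccccc2c1C(Nc1nc2ccc(Cl)cc2s1)c1cn(-c2ccccc2)nc1-c1ccccc1` is not yet measured. It differs from compound 3 by hydrogen in place of chloro on an aromatic carbon. The same kind of change, measured once, is hydrogen in place of chloro on an aromatic carbon, which gave a 2.0-fold lower number from compound 2 to compound 1 (0.30 log units; within the scatter). The two places are not identical: in the measured pair the carbon lies in a ring that is part of a fused or bridged system of two rings, meta to a fused ring and para to a fused ring, whereas in compound 3 it is meta to a large group. The cores of compound 2 and compound 3 differ by chloro in place of methoxy on an aromatic carbon, a step of a 1.6-fold lower number from compound 2 to compound 3 (0.21 log units; within the scatter).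

Because the measured step of a 2.0-fold lower number from compound 2 to compound 1 (0.30 log units; within the scatter) stayed within the scatter, compound 4 is expected to move only a little from compound 3, by about a 1.5-fold lower number from compound 3 to compound 4 (0.18 log units; within the scatter). The estimate for compound 4 in this assay is 12000 nM, between 5000 nM and 35000 nM.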

Compound 4, half-maximal inhibitory concentration: 12500 nM
Compound 4: the middle estimate sits 1.0-fold (0.02 log units) below what was measured, within the range that was stated.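

In this assay swapping chloro for hydrogen on the 3-chlorophenyl group gives a 1.5-fold lower number from compound 3 to compound 4 (0.17 log units; within the scatter) and this can be set beside the same swap on another core: the same change on two cores in this assay, a 2.0-fold lower number (0.30 log units; within the scatter) from compound 2 to compound 1 and a 1.5-fold lower number (0.17 log units; within the scatter) from compound 3 to compound 4, 1.4-fold (0.14 log units) apart, within the scatter of two such steps.

Among these compounds, the change therefore carries over between these two cores with no difference that can be told apart, yet with only two pairs, each step itself within the scatter, this shows that it stayed small here and not that it would stay small on every core. Replacing methoxy with hydrogen gives a 2.4-fold lower number from compound 2 to compound 4 (0.38 log units; beyond the scatter) and this modest step rests on a single pair.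

The compounds shown leave open what other groups would do at the same place on that ring, such as an amine, a carboxylic acid or a longer chain.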